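A few compounds are considered here, and "the series" means these few. Any claim that something is new, unique, unknown or untested is made for them only; others in the source may bear on it.

Among the compounds with values here, compound 1 `CCc1ccccc1NS(=O)(=O)c1ccc(N2CCNC2=O)cc1` gives 180 nM in a functional assay on M21 cells (Homo sapiens) for antiproliferative activity, read by sulforhodamine B assay, with a stated time of 48 h (a lower number here means a stronger inhibitor, a higher number a weaker inhibitor), the second highest of the three numbers measured so far. Compound 3 `Cc1ccc(NS(=O)(=O)c2ccc(N3CCNC3=O)cc2)c(C)c1` gives 150 nM and compound 2 `O=C1NCCN1c1ccc(S(=O)(=O)Nc2ccc(F)c(F)c2)cc1` gives 220 nM; the steps of a 1.2-fold lower number from compound 1 to compound 3 (0.08 log units; within the scatter), a 1.2-fold higher number from compound 1 to compound 2 (0.09 log units; within the scatter) and a 1.5-fold lower number from compound 2 to compound 3 (0.17 log units; within the scatter) all stay within the scatter, so exchanging one aryl group for another on the sulfonamide nitrogen has so far left this assay unchanged. Compound 4 `CCc1cccc(NS(=O)(=O)c2ccc(N3CCNC3=O)cc2)c1` differs from compound 1 only in that (3-ethylphenyl in place of 2-ethylphenyl on a sulfonamide nitrogen). Within the data shown here, no measured step moves an ethyl group around the ring, so the closest guide is this set of aryl exchanges without effect. Compound 4 is therefore expected to give about 180 nM, with a likely range of 90 nM to 360 nM. The expected step is no change at the digits printed from compound 1 to compound 4 (within the scatter), none beyond the scatter.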

Compound 4, half-maximal inhibitory concentration: 82 nM
Compound 4: the middle estimate sits 2.2-fold (0.34 log units) above what was measured; the measured number lies below the stated range.
By their numbers in this assay, from the lowest: compounds 4, 3, 1 and 2 (each within the scatter of the next, the first and the last beyond it).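

Where the ethyl group sits on the aryl ring matters in this assay: with the atoms unchanged, 3-ethylphenyl in place of 2-ethylphenyl gives a 2.2-fold lower number from compound 1 to compound 4 (0.34 log units; beyond the scatter), beyond the scatter, unlike the earlier aryl exchanges. a 2.7-fold lower number from compound 2 to compound 4 (0.43 log units; beyond the scatter) also lies beyond the scatter, whereas a 1.8-fold lower number from compound 3 to compound 4 (0.26 log units; within the scatter) stays within it, so compound 4 is not separated from compound 3. No measured property available here accounts for the shift. On these data alone, whether the gain survives a propyl chain, an amine or a carboxylic acid in place of the ethyl group remains open.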